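This account rests on a few compounds, and the source may have more. Where it says the series, first, only, none or still open, it means among the compounds named here.

Compound 1 `N#CC1CN1C(=O)Nc1ccc(F)cc1`: 2700 nM
Compound 2 `N#CC1CN1C(=O)Nc1ccc([N+](=O)[O-])cc1`: 3000 nM
Compound 3 `N#CC1CN1C(=O)Nc1ccccc1`: 4300 nM

In a functional assay on MCF7 cells (Homo sapiens) for inhibition (a higher number here means a weaker inhibitor, a lower number a stronger inhibitor), compound 3 gives 4300 nM, the highest of the three numbers, although its gaps to the other two are within the scatter. Compound 4 `N#CC1CN1C(=O)Nc1ccc(S(N)(=O)=O)cc1` is compound 3 with sulfamoyl in place of hydrogen on an aromatic carbon. Among the measured compounds shown here, the steps that bear on this change run the other way: a 1.6-fold higher number from compound 1 to compound 3 (0.20 log units; within the scatter) and a 1.4-fold higher number from compound 2 to compound 3 (0.16 log units; within the scatter) show that swapping the group at this position for hydrogen moved this assay only within the scatter. A further group at the same position is therefore expected to change little, so for compound 4 an expected 1.2-fold lower number from compound 3 to compound 4 (0.09 log units; within the scatter) is assumed, with no direction beyond the scatter. Compound 4 is thus estimated at 3500 nM, within a range from 1200 nM to 10000 nM.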

Compound 4, half-maximal inhibitory concentration: > 15000 nM
Compound 4: no number, only a limit (the forecaster's own chance of this, stated with the estimate: 10%); middle value at least 4.2-fold (0.63 log units) away from the limit.
By their numbers in this assay, from the lowest: compounds 1, 2 and 3 (each within the scatter of the next). At a limit, above all of these: compound 4.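

In this assay compound 4 has no exact number, only a limit: the limit of > 15000 nM in this assay, at which 1 of the 4 values shown sits. Even so, the position proves sensitive to what sits on it, since sulfamoyl brings an at least 3.4-fold higher number from compound 3 to compound 4 (0.54 log units; beyond the scatter), an at least 5.0-fold higher number from compound 2 to compound 4 (0.69 log units; beyond the scatter) and an at least 5.5-fold higher number from compound 1 to compound 4 (0.74 log units; beyond the scatter), a weaker result each time, while fluoro, nitro and hydrogen stay within the scatter of one another. Among these four compounds, this position therefore accepts some groups but not all.

What in sulfamoyl accounts for this stays open. So does whether a methylsulfonyl group, a carboxylic acid or an amine on the same aromatic carbon would behave like sulfamoyl or like fluoro.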